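Swapping 3-methoxyphenyl for thiophen-2-yl in compound 1

A few compounds are considered here, and "the series" means these few. Any claim that something is new, unique, unknown or untested is made for them only; others in the source may bear on it.

compound 1 `COc1cccc(/C=C/C(=O)/C=C/c2ccc(OCc3cn(CCCCOc4cc(=O)oc5ccccc45)nn3)c(OC)c2)c1`: 47%
compound 2 `COc1ccc(/C=C/C(=O)/C=C/c2ccc(OCc3cn(CCCCCOc4cc(=O)oc5ccccc45)nn3)c(OC)c2)cc1`: 39%
compound 3 `COc1ccc(/C=C/C(=O)/C=C/c2ccc(OCc3cn(CCCOc4cc(=O)oc5ccccc45)nn3)c(OC)c2)cc1`: 56%

In a functional assay on THP-1 cells (Homo sapiens) for inhibition, read by sulforhodamine B assay, with a stated time of 48 h, tested at 50 uM (a higher number here means more inhibition of growth at the concentration tested, a lower number less inhibition of growth), compound 1 gives 47%, a number within the usual scatter of both compound 2 and compound 3. Compound 4 `COc1cc(/C=C/C(=O)/C=C/c2cccs2)ccc1OCc1cn(CCCCOc2cc(=O)oc3ccccc23)nn1` has not yet been measured. It differs from compound 1 in one place: thiophen-2-yl in place of 3-methoxyphenyl on a double-bonded chain carbon bound to a double-bonded chain carbon. Thiophen-2-yl stands in place of 3-methoxyphenyl on a double-bonded chain carbon bound to a double-bonded chain carbon. Among the measured compounds shown here, no measured pair shows this change alone, so the data give no direction for it, and no shift beyond the scatter is expected. The expected step is a number 2 percentage points lower from compound 1 to compound 4 (within the scatter). The estimate for compound 4 is 45%, with an expected range of 30% to 60%.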

Compound 4, percent growth inhibition at one concentration: 44%
Compound 4: the middle estimate sits 1 percentage points above what was measured; low and high end bracket the measured number.
By their numbers in this assay, from the lowest: compounds 2, 4, 1 and 3 (each within the scatter of the next, the first and the last beyond it).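

Among the compounds shown here, the step of a number 3 percentage points lower from compound 1 to compound 4 (within the scatter) in this assay is the first reading of this change, thiophen-2-yl in place of 3-methoxyphenyl on a double-bonded chain carbon. At this one concentration, then, a five-membered aromatic ring with sulfur serves here about as well as the methoxy-bearing six-membered carbon ring. No measurement at hand bears on why.

From the compounds shown here alone, whether a ring carrying an amine or a carboxylic acid would fit this place equally well stays open. So does the effect of a longer chain here.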